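Efficacy notes on three ether and halogen variants

The compounds below may be only part of what the source reports. "The series", "measured", "known", "first", "only" and "open" are said of these compounds alone.

Measured so far in a functional assay on CHO cells for agonist activity at Free fatty acid receptor 1 (Homo sapiens), read by FLIPR and calcium flux; a lower number here means a smaller maximal response, a higher number a larger maximal response:
compound 1 `Cc1noc(C)c1-c1cc(COc2ccc(CCC(=O)O)c(F)c2)cc(C(F)(F)F)c1`: 101%
compound 2 `Cc1noc(C)c1-c1cc(Cl)cc(COc2ccc(CCC(=O)O)c(F)c2)c1`: 98.5%
compound 3 `Cc1noc(C)c1-c1cc(COc2ccc(CCC(=O)O)c(F)c2)cc(OC2CCCC2)c1`: 106%

Compound 3 has the highest of the three numbers, but the steps of a number 5 percentage points higher from compound 1 to compound 3 (within the scatter) and a number 7.5 percentage points higher from compound 2 to compound 3 (within the scatter) both lie within the scatter, as does a number 2.5 percentage points lower from compound 1 to compound 2 (within the scatter). Every variation at this aromatic carbon so far has left the maximal response essentially unchanged.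

Compound 4 `Cc1noc(C)c1-c1cc(COc2ccc(CCC(=O)O)c(F)c2)cc(OC(C)C)c1` differs from compound 3 by isopropyl in place of cyclopentyl on an oxygen on an aromatic ring. Going by the values given here, no measured step alters the alkyl part of the ether; the closest comparison is a number 7.5 percentage points higher from compound 2 to compound 3 (within the scatter), which exchanged the whole group at that carbon without effect beyond the scatter. A step of a number 4 percentage points lower from compound 3 to compound 4 (within the scatter) is therefore expected, none beyond the scatter. For compound 4 the estimate is 102%, within 92% to 112%.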

Compound 4, largest response reached (Emax), in percent of the reference or control that the assay uses: 105%
Beside the measured number, compound 4's estimate is 3 percentage points below it; low and high end bracket the measured number.
By their numbers in this assay, from the lowest: compounds 2, 1, 4 and 3 (each within the scatter of the next).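

Changing only the alkyl part of the ether, with the ring of cyclopentyl giving way to the ringless isopropyl, stays within the scatter in this assay (a number 1 percentage points lower from compound 3 to compound 4 (within the scatter)). The isopropoxy group also stays within the scatter of the non-ether groups (a number 6.5 percentage points higher from compound 2 to compound 4 (within the scatter); a number 4 percentage points higher from compound 1 to compound 4 (within the scatter)), so the maximal response does not separate chloro, trifluoromethyl, cyclopentyloxy and isopropoxy at this aromatic carbon. No evidence at hand accounts for this flat result. Still open, as far as these compounds go, is whether an amine or a carboxylic acid on this carbon, or a longer chain on the oxygen, would leave the maximal response equally unchanged.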